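Chloro in place of methyl on the aryl of compound 2

A few compounds are considered here, and "the series" means these few. Any claim that something is new, unique, unknown or untested is made for them only; others in the source may bear on it.

Compound 2 `Cc1ccccc1-c1nc(N)nc(N)n1` stands lowest of the two numbers in hand: in a functional assay on the whole organism with Rattus norvegicus as the target, at a dose of 20 mg/kg by the intraperitoneal route (on this read-out higher numbers stand for more inhibition at the one dose given (going by the name of the read-out) and lower numbers for less inhibition), compound 2 gives 28%, while compound 1 `Nc1nc(N)nc(-c2c(Cl)cccc2Cl)n1` gives 54%, a gap beyond the scatter. Compound 3 `Nc1nc(N)nc(-c2ccccc2Cl)n1` is not yet measured; it differs from compound 2 by chloro in place of methyl on an aromatic carbon. Among the measured compounds shown here, no step between measured compounds carries this same change. Since compound 1, bearing chloro rather than methyl, gives 54%, an upward step of moderate size is expected a number 12 percentage points higher from compound 2 to compound 3 (beyond the scatter). Compound 3 is estimated at 40%, within 22% to 58%.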

Compound 3, a percentage reported as inhibition, in the whole organism at one dose (the size of the read-out at that dose, not a potency) in the Rattus norvegicus assay: 36%
For compound 3 the middle estimate is 4 percentage points above the measured one; the range from low to high includes it.
By their numbers in the Rattus norvegicus assay, from the lowest: compounds 2 and 3 (each within the scatter of the next); then compound 1.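

In the Rattus norvegicus assay the change gives a number 8 percentage points higher from compound 2 to compound 3 (within the scatter) and so does not separate chloro from methyl on this aromatic carbon. In the Rattus norvegicus assay hydrogen in place of chloro gives a number 18 percentage points lower from compound 1 to compound 3 (beyond the scatter) and so the second chloro of compound 1 is what sets it apart from compound 3. In a physicochemical assay for lipophilicity (on this read-out lower numbers stand for lower lipophilicity and higher numbers for higher lipophilicity), compound 2 gives 1.26 and compound 3 gives 1.19 as values within the scatter of each other, and nothing on hand explains either step.

From the compounds shown here alone, whether a methoxy or an amine on this aromatic carbon would move the inhibition beyond the scatter stays open.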